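The source may hold more compounds than are shown below. What is called first, only, known or untested is meant among the compounds shown, and "the series" means these compounds.

Compound 1 `N#Cc1ccc(CN[C@@H]2CN[C@H](C(=O)N3CCSC3)C2)cc1` is the one entry with a plain number in an assay on a cell-free system (plasma) for inhibition of Dipeptidyl peptidase 4 (Rattus norvegicus), read by fluorescence; a higher number here means a weaker inhibitor, a lower number a stronger inhibitor: compound 1 reaches 34.3 nM. Compound 2 `O=C([C@@H]1C[C@H](NS(=O)(=O)c2ccccc2)CN1)N1CCSC1` sits at a limit of the test, > 300 nM, which is a boundary rather than a measured number. Compound 3 `N#Cc1ccc(C(=O)O[C@@H]2CN[C@H](C(=O)N3CCSC3)C2)cc1` likewise sits at the limit > 300 nM. Compound 1 therefore stands apart from the limit of > 300 nM in this assay, at which 2 of the 3 values shown sit. Compound 4 `N#Cc1ccc(CN(CC(=O)O)[C@@H]2CN[C@H](C(=O)N3CCSC3)C2)cc1` differs from compound 1 by carboxymethyl in place of hydrogen on an amine nitrogen. Among the measured compounds shown here, no measured pair shows what such a change does here, so the expectation rests on compound 1 alone. The step is expected to be a modest weakening estimated as a 2.3-fold higher number from compound 1 to compound 4 (0.37 log units; beyond the scatter). Compound 4 is estimated at 80 nM, within 20 nM to 400 nM.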

Compound 4, half-maximal inhibitory concentration: 16.3 nM
The estimate for compound 4 lay 4.9-fold (0.69 log units) above the measured number, outside the stated range (below it).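

In this assay, the amine nitrogen of compound 1 takes carboxymethyl in place of hydrogen and gives a 2.1-fold lower number from compound 1 to compound 4 (0.32 log units; beyond the scatter), so a low number here does not depend on that nitrogen keeping its hydrogen. Among the compounds shown here, this single step is the only evidence for that position. Compound 2 and compound 3 remain at a limit of the test, which is no measured number: the limit of > 300 nM in this assay, at which 2 of the 4 values shown sit.

Going by these compounds, whether the gain comes from the acid or simply from the added chain stays open. A methyl, the methyl ester of the acid, or a longer chain ending in a carboxylic acid on the same nitrogen would help separate these.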